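Fluorinated phenoxy groups on the shared core: the next step

A few compounds are considered here, and "the series" means these few. Any claim that something is new, unique, unknown or untested is made for them only; others in the source may bear on it.

Values so far in a functional assay on Jurkat cells (Homo sapiens) (on this read-out lower numbers stand for stronger inhibition and higher numbers for weaker inhibition), are these
- compound 1 `CC(C)[C@H](NC(=O)COc1cccc2ccccc12)C(=O)N[C@@H](CC(=O)O)C(=O)COc1ccc(-c2ccccc2)cc1` gives 87900 nM
- compound 2 `CC(C)[C@H](NC(=O)COc1cccc2ccccc12)C(=O)N[C@@H](CC(=O)O)C(=O)COc1ccccc1F` gives > 100000 nM as a limit of the assay
- compound 3 `CC(C)[C@H](NC(=O)COc1cccc2ccccc12)C(=O)N[C@@H](CC(=O)O)C(=O)COc1cc(F)cc(F)c1F` gives 30000 nM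

For the measured compounds named here, compound 3 holds the lowest number so far, with compound 1 the nearest value above it. The next compound is compound 4 `CC(C)[C@H](NC(=O)COc1cccc2ccccc12)C(=O)N[C@@H](CC(=O)O)C(=O)COc1cccc(C(F)(F)F)c1F`, which has 2-fluoro-3-(trifluoromethyl)phenyl in place of 2,3,5-trifluorophenyl on an oxygen on a saturated carbon. Two measured steps act at this same place. a 2.9-fold lower number from compound 1 to compound 3 (0.47 log units; beyond the scatter) and an at least 3.3-fold lower number from compound 2 to compound 3 (0.52 log units; beyond the scatter) are both beyond the scatter, and the second is only a floor that rests on the limit of > 100000 nM in this assay, at which 1 of the 3 values shown sits, and no exact number. Going by the values given here, no measured compound carries a trifluoromethyl group, so the data isolate no effect for it. The size of an at least 3.3-fold lower number from compound 2 to compound 3 (0.52 log units; beyond the scatter) suggests that the aryl group of compound 3 cannot be exchanged freely, so a small rise, not beyond the scatter, is expected. The estimated change is a 1.3-fold higher number from compound 3 to compound 4 (0.12 log units; within the scatter) in this read-out. For compound 4 the estimated value is 40000 nM with an expected range of 12000 nM to 100000 nM in this assay.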

Compound 4, half-maximal inhibitory concentration: 50400 nM
Compound 4: the middle estimate sits 1.3-fold (0.10 log units) below what was measured; the measured number falls inside the stated range.
By their numbers in this assay, from the lowest: compounds 3, 4 and 1 (each within the scatter of the next, the first and the last beyond it). At a limit, above all of these: compound 2.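

In this assay, 2-fluoro-3-(trifluoromethyl)phenyl in place of 2,3,5-trifluorophenyl on this oxygen gives a 1.7-fold higher number from compound 3 to compound 4 (0.23 log units; within the scatter), so a trifluoromethyl-bearing aryl group here cannot be told apart from the trifluorinated one. Compound 4 also cannot be told apart from the 4-phenylphenyl compound, with a 1.7-fold lower number from compound 1 to compound 4 (0.24 log units; within the scatter), even though the two compounds on either side of it differ by a 2.9-fold lower number from compound 1 to compound 3 (0.47 log units; beyond the scatter). Trifluoromethyl in place of hydrogen on an aromatic carbon gives an at least 1.9-fold lower number from compound 2 to compound 4 (0.29 log units; that floor lies within the scatter), and that step is only a floor, as the value of compound 2 is a limit: the limit of > 100000 nM in this assay, at which 1 of the 4 values shown sits.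

As far as these compounds go, whether an amine, a nitrile or a carboxylic acid on the phenoxy ring would change the number at this place stays open. From the compounds shown here alone, compound 3 gives 30000 nM, and whether any other aryl group here goes clearly further down is also open.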